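A New Arm on the Ring Nitrogen of Compound 1

A few compounds are considered here, and "the series" means these few. Any claim that something is new, unique, unknown or untested is made for them only; others in the source may bear on it.

Compound 1, `NC(=O)c1c(NC(=O)c2ccccc2Cl)sc2c1CCN(Cc1ccc(Cl)cc1)C2`, was tested in a functional assay on MKN-74 cells (Homo sapiens) for antiproliferative activity, with a stated time of 24 h (a higher number here means a weaker inhibitor, a lower number a stronger inhibitor), where compound 1 gives 18700 nM. Among the two plain numbers in this small set, that is the highest. The nearest neighbour is compound 3, `NC(=O)c1c(NC(=O)c2ccccc2F)sc2c1CCN(Cc1ccc(Cl)cc1Cl)C2`, for which this assay gives 9610 nM; the gap between compound 1 and compound 3 lies within the usual scatter, so the two cannot be told apart. Compound 2, `NC(=O)c1c(NC(=O)c2ccc(C(F)(F)F)cc2)sc2c1CCN(Cc1ccc(Cl)cc1)C2`, reaches only a limit of this assay, > 50000 nM. For the measured compounds named here, the one step between measured compounds, an at least 2.6-fold higher number from compound 1 to compound 2 (0.42 log units; beyond the scatter), ends at that limit (the limit of > 50000 nM in this assay, at which 1 of the 3 values shown sits).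

Compound 4, `NC(=O)c1c(NC(=O)c2ccccc2Cl)sc2c1CCN(C(=S)Nc1c(Cl)cccc1Cl)C2`, differs from compound 1 at another place: a group of 11 heavy atoms (7 carbon, 1 nitrogen, 1 sulfur, 2 chlorine; one six-membered aromatic ring of carbon only) in place of a group of 8 heavy atoms (7 carbon, 1 chlorine; one six-membered aromatic ring of carbon only), on an amine nitrogen in a ring. Going by the values given here, the only measured step swaps the ring on the carbonyl carbon and leaves the group on the amine nitrogen untouched, so no measured step speaks to this change. The expectation therefore rests on compound 1 alone, with wide uncertainty and a real chance that this assay again reports only a limit. Compound 4 is expected to give 15000 nM in this assay, between 4000 nM and 50000 nM. The expected step, a 1.2-fold lower number from compound 1 to compound 4 (0.10 log units; within the scatter), amounts to no change beyond the scatter.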

Compound 4, half-maximal inhibitory concentration: 4020 nM
Beside the measured number, compound 4's estimate is 3.7-fold (0.57 log units) above it; measured number inside the range.
By their numbers in this assay, from the lowest: compound 4; then compounds 3 and 1 (each within the scatter of the next). At a limit, above all of these: compound 2.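

For the compounds shown here, until now the only measured step changed the ring on the carbonyl carbon, so this is the first reading on the amine nitrogen in the ring. In this assay, replacing 4-chlorobenzyl with the larger group, which brings sulfur, a further nitrogen, a double bond outside aromatic rings, a hydrogen-bond donor and a hydrogen-bond acceptor, gives a 4.7-fold lower number from compound 1 to compound 4 (0.67 log units; beyond the scatter), so this position can take a quite different group and the number still falls. Compound 2 remains the only compound at a limit: the limit of > 50000 nM in this assay, at which 1 of the 4 values shown sits.

The swap changes several things at once, including the atoms linking the aromatic ring to the nitrogen and the chlorines on that ring, so the compounds shown cannot say which of these parts goes with the lower number. They also leave open whether a version with oxygen in place of the sulfur, or a much smaller group on the same nitrogen such as methyl or acetyl, would give a similar number.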